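The source may report more compounds than this note shows. Statements on the series, on what has been measured and on what is new or still open speak of the compounds shown alone.

In a functional assay on PANC-1 cells (Homo sapiens) for inhibition, read by MTT assay, with a stated time of 24 h, tested at 10 uM (on this read-out higher numbers stand for more inhibition at the one concentration tested (going by the name of the read-out) and lower numbers for less inhibition), three compounds have been measured so far:

compound 1 `CCOc1cc(=O)n(CCCO)c2c1CC(CC=C(C)C)C(C)(C)C2` gives 66.5%;
compound 2 `CC(C)=CCC1Cc2c(OCCCNC(=O)c3cccs3)cc(=O)n(CCCO)c2CC1(C)C` gives 33.6%;
compound 3 `CC(C)=CCC1Cc2c(OC(=O)Nc3ccccc3F)cc(=O)n(CCCO)c2CC1(C)C` gives 52.3%.

Compound 3 therefore stands second highest of the three on this assay: the step of a number 14.2 percentage points lower from compound 1 to compound 3 (beyond the scatter) puts it beneath compound 1, while the step of a number 18.7 percentage points higher from compound 2 to compound 3 (beyond the scatter) puts it above compound 2, both beyond the scatter.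

The unmeasured compound 4 `CC(C)=CCC1Cc2c(OC(=O)Nc3ccc(F)cc3F)cc(=O)n(CCCO)c2CC1(C)C` differs from compound 3 by a single change: fluoro in place of hydrogen on an aromatic carbon. Among the measured compounds shown here, no measured step alters a fluoro on that ring. The two steps that bring the (2-fluorophenyl)carbamoyl group in, a number 14.2 percentage points lower from compound 1 to compound 3 (beyond the scatter) and a number 18.7 percentage points higher from compound 2 to compound 3 (beyond the scatter), concern the whole group and so bear on this change only at one remove; they show the group can be carried without losing most of the inhibition, but say nothing about a second fluoro. With nothing closer to lean on, a step within the scatter is expected, and the change is estimated as a number 0.3 percentage points lower from compound 3 to compound 4 (within the scatter). Compound 4 is thus expected to give about 52% in this assay, within a range from 36% to 68%.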

Compound 4, a percentage reported as inhibition, at one concentration (the size of the read-out at that concentration, not a potency): 69.7%
Compound 4: middle estimate off by 17.7 percentage points, on the low side; the measured number lies above the stated range.
By their numbers in this assay, from the lowest: compound 2; then compound 3; then compounds 1 and 4 (each within the scatter of the next).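

Among the compounds shown here, the aromatic carbon para to a large group and meta to the fluoro group proves responsive in this assay: fluoro in place of hydrogen there gives a number 17.4 percentage points higher from compound 3 to compound 4 (beyond the scatter) and is the only measured change on this ring. On the oxygen on the aromatic ring, the (2,4-difluorophenyl)carbamoyl group gives a number 3.2 percentage points higher from compound 1 to compound 4 (within the scatter) against ethyl, so the two compounds cannot be told apart, and it gives a number 36.1 percentage points higher from compound 2 to compound 4 (beyond the scatter) against the 3-(((thiophen-2-yl)carbonyl)amino)propyl group. Nothing given here accounts for the size of the fluoro step.

The compounds shown leave open whether a chloro, a methoxy or an amine on the same carbon would move the number as fluoro does. They also leave open whether a 4-fluorophenyl group, with no fluoro at the 2 position, would keep the higher number.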